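This account rests on a few compounds, and the source may have more. Where it says the series, first, only, none or still open, it means among the compounds named here.

Compound 1, `COc1cc(NC(C)CCCNC(=O)NCc2ccncc2)c2ncccc2c1`, in an ADME assay on HEL cells (Homo sapiens) for cytotoxicity (a higher number here means that more compound is tolerated, a lower number that less compound is tolerated), gives 72000 nM. Compound 2, `CCN(CC)C(=O)NCCCC(C)Nc1cc(OC)cc2cccnc12`, in this assay reaches only a limit of the assay, > 100000 nM.

Compound 2 thus stands at the limit of > 100000 nM in this assay, at which 1 of the 2 values shown sits, without a number of its own. Compound 3, `COc1cc(NC(C)CCCNC(=O)n2nnc3ccccc32)c2ncccc2c1`, differs from it by a group of 9 heavy atoms (6 carbon, 3 nitrogen; one five-membered aromatic ring with 3 hetero atoms, one six-membered aromatic ring of carbon only) in place of a group of 5 heavy atoms (4 carbon, 1 nitrogen; no ring), on a carbonyl carbon. Among the measured compounds shown here, the only measured step at that carbonyl carbon, an at least 1.3-fold higher number from compound 1 to compound 2 (0.14 log units; that floor lies within the scatter), stays within the scatter, so the exchange of the group there gave no clear change. Compound 3 is therefore expected to remain near the limit, with an expected step of an at least 1.3-fold lower number from compound 2 to compound 3 (0.14 log units; that floor lies within the scatter). The estimate for compound 3 in this assay is 72000 nM, between 30000 nM and 150000 nM.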

Compound 3, half-maximal cytotoxic concentration: 72000 nM
Estimate against measurement, compound 3: no gap at the digits printed; measured number inside the range.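

Among the compounds shown here, exchanging the ((pyridin-4-yl)methyl)amino group on the carbonyl carbon for the larger group with two aromatic rings gives, in this assay, no change at the digits printed from compound 1 to compound 3 (within the scatter), the first pair at this position with a number on both sides. The step from the diethylamino group reads an at least 1.3-fold lower number from compound 2 to compound 3 (0.14 log units; that floor lies within the scatter). That step is only a floor, because compound 2 has a limit and no number of its own: the limit of > 100000 nM in this assay, at which 1 of the 3 values shown sits.

The compounds shown leave open whether a morpholine or a piperazine on the carbonyl carbon would shift the value beyond the scatter. They also leave open how far compound 2 truly lies from compound 3.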